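A few compounds are considered here, and "the series" means these few. Any claim that something is new, unique, unknown or untested is made for them only; others in the source may bear on it.

In a physicochemical assay for solubility, measured as kinetic solubility, with a stated time of 1 h, at pH 7.4 (on this read-out higher numbers stand for higher solubility and lower numbers for lower solubility), compound 1 `N#CCCC(=O)NC1=NN(c2ccc(Cl)c(Cl)c2)CC1` gives 39000 nM and compound 2 `O=C(NC1=NN(c2ccc(Cl)c(Cl)c2)CC1)c1cncnc1` gives 8000 nM as the lower of the two numbers. Compound 3 `O=C(NC1=NN(c2ccc(Cl)c(Cl)c2)CC1)c1cccnc1F` keeps the shared core and carries 2-fluoropyridin-3-yl in place of pyrimidin-5-yl on a carbonyl carbon. Among the compounds with values here, the one measured step at that place (a 4.9-fold lower number from compound 1 to compound 2 (0.69 log units; beyond the scatter)) is modest but beyond the scatter, and it replaced a different group, so it offers only a loose guide. In this assay a small downward step, probably within the scatter, is expected (a 1.6-fold lower number from compound 2 to compound 3 (0.20 log units; within the scatter)). Compound 3 is expected near 5000 nM (estimated range 1500 nM to 16000 nM).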

Compound 3, solubility: 13000 nM
The estimate for compound 3 lay 2.6-fold (0.41 log units) below the measured number, and the stated range covers the measured number.
By their numbers in this assay, from the lowest: compounds 2 and 3 (each within the scatter of the next); then compound 1.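

Swapping one aromatic group for another on the carbonyl carbon in this assay leaves the two compounds within the usual scatter (a 1.6-fold higher number from compound 2 to compound 3 (0.21 log units; within the scatter)), even though the entering ring has one hetero atom fewer and brings a fluorine. Both aromatic groups give lower numbers than the 2-cyanoethyl chain of compound 1 (a 4.9-fold lower number from compound 1 to compound 2 (0.69 log units; beyond the scatter); a 3.0-fold lower number from compound 1 to compound 3 (0.48 log units; beyond the scatter)), so at this place the second aromatic group behaves like the first. Nothing available explains these steps. Still open, going by these compounds, is how an amine or a carboxylic acid on this carbonyl carbon would compare with these groups.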